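The source may hold more compounds than are shown below. What is called first, only, known or untested is meant among the compounds shown, and "the series" means these compounds.

Compound 1 `O=C(/C=C/c1ccc(NC(=O)Nc2ccc(Cl)c(C(F)(F)F)c2)cc1)NO`: 3400 nM
Compound 2 `O=C(Nc1ccc(Nc2ncc(C(=O)NO)cn2)cc1)Nc1ccc(Cl)c(C(F)(F)F)c1`: > 10000 nM as a limit

Both compounds were read in a functional assay on A549 cells (Homo sapiens) for inhibition, read by sulforhodamine B assay, with a stated time of 48 h; on this read-out lower numbers stand for stronger inhibition and higher numbers for weaker inhibition. For compound 2 the entry > 10000 nM is a limit of the assay and not a number. That leaves compound 2 at the limit of > 10000 nM in this assay, at which 1 of the 2 values shown sits, without an exact position. Compound 3 `O=C(Nc1ccc(NCc2ccc(C(=O)NO)cc2)cc1)Nc1ccc(Cl)c(C(F)(F)F)c1` carries 4-(hydroxycarbamoyl)benzyl in place of 5-(hydroxycarbamoyl)pyrimidin-2-yl on a nitrogen on an aromatic ring while the rest of the structure stays the same. Among the compounds with values here, no measured step covers this change. Within the data shown here, the expectation therefore leans on compound 1 at 3400 nM as the only exact reading. In this assay a moderate move toward stronger inhibition is expected, an estimated at least 3.3-fold lower number from compound 2 to compound 3 (0.52 log units; beyond the scatter) in size. Compound 3 is expected at 3000 nM with an estimated range from 800 nM to 10000 nM until its measurement is known.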

Compound 3, half-maximal inhibitory concentration: 4300 nM
Estimate against measurement, compound 3: 1.4-fold (0.16 log units) below; measured number inside the range.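

At this place, on a nitrogen on an aromatic ring, the group carried does matter in this assay: 4-(hydroxycarbamoyl)benzyl in place of 5-(hydroxycarbamoyl)pyrimidin-2-yl gives an at least 2.3-fold lower number from compound 2 to compound 3 (0.36 log units; beyond the scatter). The change alters two things at once, replacing a six-membered aromatic ring with 2 hetero atoms by one of carbon only and a ring set directly on the nitrogen by a benzyl group. For compound 2 the reading is a limit of the assay and not a number: the limit of > 10000 nM in this assay, at which 1 of the 3 values shown sits.

The compounds shown do not tell whether the ring atoms or the benzyl carbon account for the step. A pyrimidinylmethyl group bearing the same hydroxycarbamoyl, or a longer chain in place of the benzyl carbon, would bear on each part separately.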